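A few compounds are considered here, and "the series" means these few. Any claim that something is new, unique, unknown or untested is made for them only; others in the source may bear on it.

Measured compounds:
- Compound 1, `CCCc1nc(CC)c(C(=O)OCc2ccccc2OCCC(C)C)n1Cc1ccc(-c2ccccc2S(=O)(=O)NC(=O)OCCC(C)C)cc1F`: 10 nM
- Compound 2, `CCCc1nc(CC)c(C(=O)OCc2ccccc2S(=O)(=O)c2ccccc2)n1Cc1ccc(-c2ccccc2S(=O)(=O)NC(=O)OCCC(C)C)cc1F`: 5 nM

Both values come from an assay on isolated protein for binding affinity to Type-2 angiotensin II receptor (Homo sapiens); on this read-out lower numbers stand for stronger inhibition and higher numbers for weaker inhibition. Of the two numbers shown, compound 2 gives the lower, yet the single measured step, a 2.0-fold lower number from compound 1 to compound 2 (0.30 log units; within the scatter), lies within the scatter, so the two compounds cannot be separated with confidence.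

Compound 3, `CCCc1nc(CC)c(C(=O)OCc2ccccc2NC(=O)c2ccccc2)n1Cc1ccc(-c2ccccc2S(=O)(=O)NC(=O)OCCC(C)C)cc1F`, differs from compound 2 in one place: benzamido in place of phenylsulfonyl on an aromatic carbon. Among the compounds with values here, the only step that bears on this position is the one from compound 1 to compound 2, which also swapped the group at this same aromatic carbon and moved the number only within the scatter. On that basis, the exchange to benzamido is expected to change the number little. Compound 3 is therefore estimated at about 7 nM, with a likely range from 2.5 nM to 20 nM. The expected step, a 1.4-fold higher number from compound 2 to compound 3 (0.15 log units; within the scatter), would stay within the usual scatter.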

Compound 3, half-maximal inhibitory concentration: 1 nM
For compound 3 the middle estimate is 7.0-fold (0.85 log units) above the measured one, outside the stated range (below it).
By their numbers in this assay, from the lowest: compound 3; then compounds 2 and 1 (each within the scatter of the next).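

In this assay, the group on this aromatic carbon now makes a clear difference: benzamido in place of phenylsulfonyl gives a 5.0-fold lower number from compound 2 to compound 3 (0.70 log units; beyond the scatter) and benzamido in place of isopentyloxy gives a 10-fold lower number from compound 1 to compound 3 (1.00 log units; beyond the scatter) at the same position. Phenylsulfonyl and benzamido match in heavy-atom count and each has one six-membered aromatic ring, but only benzamido has a hydrogen-bond donor, the amide hydrogen. No measurement here explains why benzamido gives the lowest number.

From the compounds shown here alone, it remains open whether the amide hydrogen matters, which a benzamido group with a methyl on its nitrogen could test, and whether the group's benzene ring matters, which an acetamido group could test. A phenylsulfonamido group, with a sulfonyl in place of the carbonyl, would show whether the amide carbonyl can be exchanged.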